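Fluoro for hydrogen on a chalcone-like series

The source may hold more compounds than are shown below. What is called first, only, known or untested is meant among the compounds shown, and "the series" means these compounds.

Compound 1 `CC1(C)Cc2c(OCc3ccccc3)ccc(C(=O)/C=C/c3ccccc3)c2O1` is the starting point. Within the data shown here, in a functional assay on B16 cells (Mus musculus) for antiproliferative activity, read by MTT assay, with a stated time of 48 h (a lower number here means a stronger inhibitor, a higher number a weaker inhibitor), compound 1 gives 30300 nM, the only true number among the three measured compounds. Compound 2 `CC1(C)Cc2c(ccc(C(=O)/C=C/c3ccc(Cl)cc3Cl)c2OCc2ccccc2)O1` reaches only a limit of the assay, > 100000 nM. Compound 3 `CC1(C)Cc2c(ccc(C(=O)/C=C/c3cn(-c4ccccc4)nc3-c3ccccc3)c2OCc2ccccc2)O1` likewise gives a limit, > 100000 nM. Compound 1 thus stands alone with a measured value, while two others sit at the limit of > 100000 nM in this assay, at which 2 of the 3 values shown sit. Compound 4 `CC1(C)Cc2c(OCc3ccccc3)ccc(C(=O)/C=C/c3ccc(F)cc3)c2O1` differs from compound 1 by one change: fluoro in place of hydrogen on an aromatic carbon. Among the measured compounds shown here, no pair of measured compounds shows this change, so the expected step is small, in either direction, and not beyond the usual scatter. The expected step is a 1.2-fold lower number from compound 1 to compound 4 (0.08 log units; within the scatter). Compound 4 is therefore estimated at 25000 nM, within a range from 8000 nM to 80000 nM.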

Compound 4, half-maximal inhibitory concentration: > 100000 nM
Compound 4: no number, only a limit; the forecaster's own chance of this, stated with the estimate: 15%; at least 4.0-fold (0.60 log units) between middle value and limit.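

Placing fluoro on this aromatic carbon, para to a large group, is not a neutral swap in this assay: the change gives an at least 3.3-fold higher number from compound 1 to compound 4 (0.51 log units; beyond the scatter). Going by these compounds, compound 4 reaches only a limit, not a number, so the step marks the smallest possible size of this loss and its true size stays unknown. Compound 1 now stands as the only compound shown with a true number, and the others share one limit: the limit of > 100000 nM in this assay, at which 3 of the 4 values shown sit.

On these data alone, whether another group at this position, such as an amine or a carboxylic acid, would give a true number remains open.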